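Ethylamino in place of butyl on the shared core

The compounds below may be only part of what the source reports. "The series", "measured", "known", "first", "only" and "open" are said of these compounds alone.

Measured so far:
compound 1, `CCCCc1nc(N)c2nc(O)n(Cc3ccccc3)c2n1`: 0.03 uM
compound 2, `Nc1ncnc2c1nc(Cl)n2Cc1ccccc1`: > 10 uM
compound 3, `CSc1nc2c(N)ncnc2n1Cc1ccccc1`: > 10 uM

The assay throughout is a functional assay (spleen, spleen) for activation, with Mus musculus as the target; a lower number here means that less compound is needed, a higher number that more compound is needed for the effect. In this assay, among the compounds with values here, compound 1 gives 0.03 uM, the only outright number among the three values shown. For compound 2 the result is a limit of the assay, > 10 uM. For compound 3 the result is likewise a limit, > 10 uM. Within the data shown here, the only step between measured compounds that differ in one place, a step that the two limits leave unreadable from compound 2 to compound 3, therefore cannot be read, as both of its values sit at the limit of > 10 uM in this assay, at which 2 of the 3 values shown sit.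

The unmeasured compound 4, `CCNc1nc(N)c2nc(O)n(Cc3ccccc3)c2n1`, differs from compound 1 in one place: ethylamino in place of butyl on an aromatic carbon. Among the measured compounds shown here, no measured step touches this position or this exchange; compound 2 and compound 3 differ from compound 1 in other ways and give no number. The expectation for compound 4 therefore rests on compound 1 alone, with a wide range. Compound 4 is estimated at 0.1 uM, between 0.02 uM and 1 uM. The step this estimate implies, a 3.3-fold higher number from compound 1 to compound 4 (0.52 log units; beyond the scatter), is expected to be a modest loss, with little confidence in its direction.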

Compound 4, minimum effective concentration: 1 uM
Compound 4: the middle estimate sits 10-fold (1.00 log units) below what was measured; the range from low to high includes it.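

In this assay, the exchange at the aromatic carbon between two ring nitrogen atoms gives a readable result, and a large one: a 33-fold higher number from compound 1 to compound 4 (1.52 log units; beyond the scatter). Within the data shown here, the effect of the group at this position on the shared core is therefore substantial for this exchange, which the earlier compounds could not show, as they do not vary this position and the one step among them cannot be read. Compound 4 also keeps a measured number rather than a limit of the assay, so ethylamino here reduces the response without placing the compound among the values that give no number: the limit of > 10 uM in this assay, at which 2 of the 4 values shown sit.

Among these compounds, the exchange shortens the chain and brings in a nitrogen at the same time, so the single step does not separate the two changes; butylamino, which would keep the butyl chain and add the nitrogen, or propyl, which would shorten the chain with carbon alone, would be needed to tell them apart. From the compounds shown here alone, whether a longer chain than butyl, or an oxygen-linked group such as butoxy, would lower the number further also remains open.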